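The source may report more compounds than this note shows. Statements on the series, on what has been measured and on what is new or still open speak of the compounds shown alone.

Compound 2 `Cn1ccc2cc(-c3ccn4c(CC(F)(F)F)cnc4c3C#N)ccc21` gives 154% in a functional assay on CHO cells for agonist activity at metabotropic glutamate receptor 2 (Homo sapiens) (a higher number here means a larger maximal response, a lower number a smaller maximal response), the lowest of the three numbers recorded; compound 3 `N#Cc1c(-c2ccc3c(c2)OCCN3)ccn2c(CC(F)(F)F)cnc12` gives 232% and compound 1 `N#Cc1c(-c2ccc3c(ccn3[C@H]3CC[C@H](O)CC3)c2)ccn2c(CC(F)(F)F)cnc12` gives 237%. Going by the values given here, the only step between measured compounds is a number 83 percentage points lower from compound 1 to compound 2 (beyond the scatter), methyl in place of 4-hydroxycyclohexyl on an aromatic nitrogen. Compound 4 `Cn1ccc2cc(-c3ccn4c(CC(F)(F)F)cnc4c3C#N)cc(Cl)c21` differs from compound 2 by chloro in place of hydrogen on an aromatic carbon. No measured step touches this place, so the shown compounds give no indication of size or direction for this change in this assay; the default expectation is a step within the scatter, with wide uncertainty. Compound 4 is therefore expected to give about 160%, in a range of 110% to 220%, meaning an expected a number 6 percentage points higher from compound 2 to compound 4 (within the scatter).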

Compound 4, largest response reached (Emax), in percent of the reference or control that the assay uses: 184%
Compound 4: the middle estimate sits 24 percentage points below what was measured; measured number inside the range.
By their numbers in this assay, from the lowest: compound 2; then compound 4; then compounds 3 and 1 (each within the scatter of the next).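

Chloro in place of hydrogen on an aromatic carbon gives a number 30 percentage points higher from compound 2 to compound 4 (beyond the scatter) in this assay. Going by these compounds alone, this is the first reading at this position, and it shows that a single chlorine here is compatible with agonist response and moves the maximal response upward from the compound 2 baseline. Nothing available accounts for the rise. 

As far as these compounds go, whether fluoro, methyl or methoxy at the same carbon would move the response in the same direction remains open. So does whether chloro would give a similar step with 4-hydroxycyclohexyl in place of methyl on the aromatic nitrogen.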